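Swapping the Anilide Aryl Group in a Cytotoxicity Series

The source may report more compounds than this note shows. Statements on the series, on what has been measured and on what is new or still open speak of the compounds shown alone.

Three compounds have been measured in an ADME assay on HCT-116 cells (Homo sapiens) for cytotoxicity, read by MTT assay, with a stated time of 72 h; a lower number here means a stronger inhibitor, a higher number a weaker inhibitor:

Compound 1 `CCCCCN1C(=O)C/C(=C\c2cccc(C(=O)Nc3cccc(CC)c3)c2)C1=O` gives 75300 nM.
Compound 2 `COc1ccc(NC(=O)c2cccc(/C=C3\CC(=O)N(c4ccc(C)cc4)C3=O)c2)cc1` reaches only the limit of the assay, > 100000 nM.
Compound 3 `CCCCCN1C(=O)C/C(=C\c2cccc(C(=O)Nc3ccc(OC)cc3)c2)C1=O` likewise reaches only the limit of the assay, > 100000 nM.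

Compounds 1 and 3 share a core and differ in one place: 3-ethylphenyl in place of 4-methoxyphenyl on an amide-type nitrogen. In this assay this gives an at least 1.3-fold lower number from compound 3 to compound 1 (0.12 log units; that floor lies within the scatter), so the change from compound 3 to compound 1 is not resolved by the data; the value of compound 3 is only a limit, as shown by the limit of > 100000 nM in this assay, at which 2 of the 3 values shown sit.

Compounds 2 and 3 differ in their cores: 4-methylphenyl in place of pentyl on an amide-type nitrogen in a ring. Both sit at the limit, so in this assay the step is a step that the two limits leave unreadable from compound 2 to compound 3.

Compound 4 `CCc1cccc(NC(=O)c2cccc(/C=C3\CC(=O)N(c4ccc(C)cc4)C3=O)c2)c1` is not yet measured. It differs from compound 2 by 3-ethylphenyl in place of 4-methoxyphenyl on an amide-type nitrogen, which is the same change that takes compound 3 to compound 1, on the same kind of nitrogen next to a carbonyl carbon. For the measured compounds named here, from that precedent, the step in this assay is expected to be a number no higher from compound 2 to compound 4 (the limit leaves the size open), a small or unreadable step, because the only measured instance is an at least 1.3-fold lower number from compound 3 to compound 1 (0.12 log units; that floor lies within the scatter) and its starting point is a limit. The value of compound 4 in this assay is therefore estimated at 100000 nM, with a likely range from 50000 nM to 300000 nM, and a fair chance that only a limit is reported.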

Compound 4, half-maximal inhibitory concentration: 41500 nM
For compound 4 the middle estimate is 2.4-fold (0.38 log units) above the measured one; the whole stated range lies above it.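

In this assay, putting 3-ethylphenyl in place of 4-methoxyphenyl on the amide-type nitrogen gives an at least 2.4-fold lower number from compound 2 to compound 4 (0.38 log units; beyond the scatter), so on this core the change produces a step that can be read even though it starts from a limit. The change shows no sign of reversing between the two cores, but this does not establish that it carries over with the same size: the same change on two cores in this assay, an at least 1.3-fold lower number (0.12 log units; that floor lies within the scatter) from compound 3 to compound 1 and an at least 2.4-fold lower number (0.38 log units; beyond the scatter) from compound 2 to compound 4; the limit leaves it open whether they differ. With 3-ethylphenyl on the amide-type nitrogen, putting 4-methylphenyl in place of pentyl on the amide-type nitrogen in a ring gives a 1.8-fold lower number from compound 1 to compound 4 (0.26 log units; within the scatter), so this pair does not separate the two cores, and the matching step between the two 4-methoxyphenyl compounds cannot be read.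

The compounds shown leave open whether the step comes from losing the methoxy group, from gaining the ethyl group, or from where each group sits on the aromatic ring, a question that a 3-methoxyphenyl or a 4-ethylphenyl group could help to settle. Also open, as far as these compounds go, is how this assay would respond to an amine or a carboxylic acid on this aromatic ring, or to a longer chain in place of the ethyl group.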